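Swapping the Aryl Group on the Amine Nitrogen

The compounds below may be only part of what the source reports. "The series", "measured", "known", "first", "only" and "open" are said of these compounds alone.

Three measured compounds share one core and differ only in the group on a double-bonded ring carbon. Compound 1 `O=C1C=C(N2CCC2)C(=O)c2c1nc1n2[C@H]2OC[C@@H](O)[C@H]2OC1` carries azetidin-1-yl; in a functional assay on MCF7 cells (Homo sapiens) for inhibition, read by sulforhodamine B assay (on this read-out lower numbers stand for stronger inhibition and higher numbers for weaker inhibition), compound 1 reaches only a limit, > 16000 nM. Compound 2 `O=C1C=C(Nc2ccccc2F)C(=O)c2c1nc1n2[C@H]2OC[C@@H](O)[C@H]2OC1` carries (2-fluorophenyl)amino and gives 3640 nM, a step of an at least 4.3-fold lower number from compound 1 to compound 2 (0.64 log units; beyond the scatter). Compound 3 `O=C1C=C(Nc2ccc(C(F)(F)F)cc2)C(=O)c2c1nc1n2[C@H]2OC[C@@H](O)[C@H]2OC1` carries 4-(trifluoromethyl)phenyl on the amine nitrogen and likewise reaches only a limit, > 4000 nM. That step is an at least 1.0-fold higher number from compound 2 to compound 3 (0.04 log units; that floor lies within the scatter). Compound 4 `O=C1C=C(Nc2cccc(Cl)c2)C(=O)c2c1nc1n2[C@H]2OC[C@@H](O)[C@H]2OC1` differs from compound 3 by 3-chlorophenyl in place of 4-(trifluoromethyl)phenyl on an amine nitrogen. Among the compounds with values here, the one comparable aryl swap on the amine nitrogen, an at least 1.0-fold higher number from compound 2 to compound 3 (0.04 log units; that floor lies within the scatter), stayed within the scatter, so no step beyond the scatter is expected in this assay. Compound 4 is therefore estimated at 4500 nM, between 1500 nM and 14000 nM. For compound 4 this means an expected step that the limit leaves unreadable from compound 3 to compound 4.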

Compound 4, half-maximal inhibitory concentration: 4720 nM
Compound 4: the middle estimate sits 1.0-fold (0.02 log units) below what was measured, within the range that was stated.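

With 3-chlorophenyl on the amine nitrogen, a second aryl group now has a measured value that can be set against 2-fluorophenyl, and this assay shows a 1.3-fold higher number from compound 2 to compound 4 (0.11 log units; within the scatter), so these two aryl groups cannot be told apart. The gain over azetidin-1-yl also holds for this second aryl group, with an at least 3.3-fold lower number from compound 1 to compound 4 (0.53 log units; beyond the scatter). Compound 3 holds only a limit, so its step to compound 4 cannot be read: the limit of > 4000 nM in this assay, at which 1 of the 4 values shown sits.

Going by these compounds, whether a morpholine, or a phenyl carrying a carboxylic acid, on this ring carbon would move the number beyond the scatter stays open.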